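The source may hold more compounds than are shown below. What is called first, only, known or untested is meant among the compounds shown, and "the series" means these compounds.

Compound 3 `O=C(CCCCCCCCCCc1ccccc1)CC(=O)N[C@H]1CCOC1=O` is the starting point of this small set. In a functional assay on NCI-H630 cells (Homo sapiens) for cytotoxicity, read by sulforhodamine B assay, with a stated time of 5 days (on this read-out higher numbers stand for weaker inhibition and lower numbers for stronger inhibition), compound 3 gives 14000 nM. Compound 1 `O=C(CCCCCCCCCCCc1ccccc1)CC(=O)N[C@H]1CCOC1=O` differs from it by benzyl in place of phenyl on a saturated chain carbon, ten or more bonds along the chain from a carbonyl carbon. In this assay compound 1 gives 27000 nM, and that step comes to a 1.9-fold higher number from compound 3 to compound 1 (0.29 log units; within the scatter). Compound 2 `O=C(CCCCCCCCCCc1ccccc1)N[C@H]1CCOC1=O` has a different core; how it differs from the core of compound 3 is not broken down here. In this assay compound 2 gives 66000 nM, the highest number of the three, with both of its gaps to the other compounds beyond the usual scatter. Compound 4 `O=C(CCCCCCCCCCCc1ccccc1)N[C@H]1CCOC1=O` has not yet been measured. It differs from compound 2 by benzyl in place of phenyl on a saturated chain carbon, ten or more bonds along the chain from a carbonyl carbon, which is the same change as that between compound 3 and compound 1, made at the same place. The step from compound 2 to compound 4 is expected to be about a 1.4-fold higher number from compound 2 to compound 4 (0.16 log units; within the scatter) because the same change earlier gave a 1.9-fold higher number from compound 3 to compound 1 (0.29 log units; within the scatter). On that basis compound 4 is estimated at 95000 nM in this assay. For compound 4 the expected range runs from 40000 nM to 220000 nM.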

Compound 4, half-maximal inhibitory concentration: > 100000 nM
Compound 4: no number, only a limit; the forecaster's own chance of this, stated with the estimate: 25%; at least 1.0-fold (0.02 log units) between middle value and limit.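

In this assay compound 4 gives > 100000 nM, which is a limit of the assay and not a number. Putting benzyl in place of phenyl on the core of compound 2 therefore comes to an at least 1.5-fold higher number from compound 2 to compound 4 (0.18 log units; that floor lies within the scatter), and this is only a floor for the true step. The result does not speak against the change carrying over from one core to the other, but it cannot show that the change has the same size on both: the same change on two cores in this assay, a 1.9-fold higher number (0.29 log units; within the scatter) from compound 3 to compound 1 and an at least 1.5-fold higher number (0.18 log units; that floor lies within the scatter) from compound 2 to compound 4; the limit leaves it open whether they differ

Going by these compounds, how large the step on the core of compound 2 really is stays open. The compounds shown also leave open how the two cores would respond to a longer chain, or to an amine or a carboxylic acid in place of the phenyl.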